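The source may report more compounds than this note shows. Statements on the series, on what has been measured and on what is new or still open speak of the compounds shown alone.

Of the compounds shown here, two with a shared core have numbers so far. Among the measured compounds shown here, in an ADME assay on MT4 cells (Homo sapiens) for cytotoxicity, read by MTT assay, with a stated time of 4 days (on this read-out lower numbers stand for higher toxicity in this test and higher numbers for lower toxicity in this test), compound 2 `Cc1ccc(-c2c(C)c(-c3ccc(Cl)cc3)c(C(OC(C)(C)C)C(=O)O)c(C)c2NS(C)(=O)=O)cc1C` gives 26000 nM and compound 1 `Cc1ccc(-c2c(C)c(-c3ccc(Cl)c(F)c3)c(C(OC(C)(C)C)C(=O)O)c(C)c2NS(C)(=O)=O)cc1C` gives 22000 nM, so compound 2 stands within the scatter of the only other value available. Compound 3 `Cc1ccc(-c2c(C)c(-c3ccc4c(c3)CCCO4)c(C(OC(C)(C)C)C(=O)O)c(C)c2NS(C)(=O)=O)cc1C` has not yet been measured. It differs from compound 2 by a group of 10 heavy atoms (9 carbon, 1 oxygen; one six-membered non-aromatic ring with 1 hetero atom, one six-membered aromatic ring of carbon only) in place of a group of 7 heavy atoms (6 carbon, 1 chlorine; one six-membered aromatic ring of carbon only), on an aromatic carbon on an aromatic carbon, para to a methanesulfonamido group and ortho to a carboxy(tert-butoxy)methyl group. The 4-chlorophenyl group leaves, and in its place enters a group that adds a six-membered non-aromatic ring with 1 hetero atom. For the measured compounds named here, only one measured step bears on this, namely a 1.2-fold higher number from compound 1 to compound 2 (0.07 log units; within the scatter), where hydrogen takes the place of fluoro on an aromatic carbon. Going by the values given here, that step is small and is a much smaller change, and no measured compound carries the entering ring, so the guidance from this assay is thin. The expected result is a 1.0-fold lower number from compound 2 to compound 3 (0.02 log units; within the scatter) and no shift beyond the scatter is foreseen. For compound 3 the estimated value is 25000 nM, with an expected range from 11000 nM to 55000 nM.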

Compound 3, half-maximal cytotoxic concentration: 28000 nM
Compound 3: middle estimate off by 1.1-fold (0.05 log units), on the low side; measured number inside the range.
By their numbers in this assay, from the lowest: compounds 1, 2 and 3 (each within the scatter of the next).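

In this assay, replacing the 4-chlorophenyl group with the larger ring-bearing group on the aromatic carbon para to a methanesulfonamido group gives a 1.1-fold higher number from compound 2 to compound 3 (0.03 log units; within the scatter), and the comparison with the chloro-fluoro aryl group gives a 1.3-fold higher number from compound 1 to compound 3 (0.10 log units; within the scatter). The earlier compounds shown here had tested only the exchange of fluoro for hydrogen, whereas this result shows that a much larger replacement at this position, which removes the chlorine and adds a six-membered non-aromatic ring with a hetero atom and a hydrogen-bond acceptor, also stays within the scatter. No supporting measurement is available to say why the read-out holds across these groups.

On these data alone, all three compounds keep a six-membered aromatic ring of carbon only on this carbon, so it remains open whether a pyridine ring, a piperidine ring carrying a free amine, or a simple longer alkyl chain there would leave the number in the same place. As far as these compounds go, it is also open whether a carboxylic acid added to the aryl group would change the picture, and whether the same tolerance holds on any read-out other than this one.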